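Alkoxy variation at the aryl ketone in a chalcone series

The source may hold more compounds than are shown below. What is called first, only, known or untested is meant among the compounds shown, and "the series" means these compounds.

Measured compounds:
Compound 1 `CCOc1ccc(C(=O)/C=C/c2c(/C=C/c3ccc(OC)cc3)cc(OC)cc2OC)cc1`: 7.5 ug/mL
Compound 2 `COc1ccc(/C=C/c2cc(OC)cc(OC)c2/C=C/C(=O)c2ccccc2)cc1`: 3.9 ug/mL
Compound 3 `CCCCCCOc1ccc(C(=O)/C=C/c2c(/C=C/c3ccc(OC)cc3)cc(OC)cc2OC)cc1`: 8.4 ug/mL

Of the compounds shown here, three sharing one core have been tested in a functional assay on A549 cells (Homo sapiens) for antiproliferative activity, read by MTT assay, with a stated time of 48 h; a lower number here means a stronger inhibitor, a higher number a weaker inhibitor. Compound 2 has the lowest number of the three, but its gap to compound 1 is within the scatter, so it cannot be called the strongest; only compound 3 sits clearly apart from it.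

Compound 4 `CCCC(C)Oc1ccc(C(=O)/C=C/c2c(/C=C/c3ccc(OC)cc3)cc(OC)cc2OC)cc1` is not yet measured. Relative to compound 2 it carries 1-methylbutoxy in place of hydrogen on an aromatic carbon.

Within the data shown here, two measured steps bear on this change. Removing the ethoxy gave a 1.9-fold lower number from compound 1 to compound 2 (0.28 log units; within the scatter), a difference that does not rise above the scatter. Adding the hexyloxy gave a 2.2-fold higher number from compound 2 to compound 3 (0.33 log units; beyond the scatter), a modest but real weakening. Both ether-bearing compounds, 1 and 3, therefore lie at higher numbers than compound 2, and the 1-methylbutoxy of compound 4 is intermediate in chain length between those two groups. The expectation is thus for a small upward step, a 1.9-fold higher number from compound 2 to compound 4 (0.28 log units; within the scatter), landing compound 4 near compounds 1 and 3 rather than improving on compound 2. The estimate for compound 4 is 7.5 ug/mL, with a range from 4 ug/mL to 14 ug/mL.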

Compound 4, half-maximal inhibitory concentration: 9.4 ug/mL
Compound 4: middle estimate off by 1.3-fold (0.10 log units), on the low side; the range from low to high includes it.
By their numbers in this assay, from the lowest: compounds 2, 1, 3 and 4 (each within the scatter of the next, the first and the last beyond it).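

In this assay the 1-methylbutoxy group, on an aromatic carbon para to a large group, gives a 2.4-fold higher number from compound 2 to compound 4 (0.38 log units; beyond the scatter) and so sits clearly apart from the bare phenyl of compound 2, as the hexyloxy of compound 3 did, while the ethoxy of compound 1 stays within the scatter of compound 2. The new compound also shows that branching the chain near the oxygen has no readable effect here: the change from hexyl to 1-methylbutyl gives a 1.1-fold higher number from compound 3 to compound 4 (0.05 log units; within the scatter) and the extension from ethoxy gives a 1.3-fold higher number from compound 1 to compound 4 (0.10 log units; within the scatter) and neither step rises above the scatter, so these three ethers cannot be told apart at this position. No measurement shown offers an explanation for the difference from the unsubstituted compound 2.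

The compounds shown leave open whether a methoxy, the shortest ether, would stay with compound 2 or join the other three compounds. They also leave open whether a group of another kind on this aromatic carbon, such as an amine or a carboxylic acid, would move the number further from that of compound 2 in either direction.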